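The compounds below may be only part of what the source reports. "The series", "measured", "known", "first", "only" and "open" are said of these compounds alone.

In a functional assay on MCF7 cells (Homo sapiens) for cytotoxicity, read by MTT assay, with a stated time of 24 h (on this read-out lower numbers stand for stronger inhibition and higher numbers for weaker inhibition), compound 1 `Cn1cnnc1SCC(=O)Nc1ccc(-c2nc(-c3ccccc3)c(-c3ccccc3)n2C)cc1` gives 3.2 ug/mL, and compound 2 `Cc1nnc(SCC(=O)Nc2ccc(-c3nc(-c4ccccc4)c(-c4ccccc4)n3C)cc2)s1` gives 3.2 ug/mL. Within the data shown here, compound 2 therefore stands level with compound 1, its only measured neighbour. Compound 3 `CN(C)/C=C/N1CCN(CC(=O)Nc2ccc(-c3nc(-c4ccccc4)c(-c4ccccc4)n3C)cc2)CC1` keeps the shared core and the carbonyl but changes the group that hangs from the chain: 4-(2-(dimethylamino)ethenyl)piperazin-1-yl in place of (5-methyl-1,3,4-thiadiazol-2-yl)sulfanyl on a saturated chain carbon bound to a carbonyl carbon. In words, 4-(2-(dimethylamino)ethenyl)piperazin-1-yl takes the place of (5-methyl-1,3,4-thiadiazol-2-yl)sulfanyl on a saturated chain carbon bound to a carbonyl carbon.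

Among the measured compounds shown here, only a single measured step bears on this change: no change at the digits printed from compound 1 to compound 2 (within the scatter). That step exchanged 4-methyl-4H-1,2,4-triazol-3-yl for 5-methyl-1,3,4-thiadiazol-2-yl on a sulfur, so the sulfur stayed in place. It shows that this site tolerated one swap of rings, but it says little about a change that removes both the sulfur and the aromatic ring. For the measured compounds named here, no measured compound carries the new group, so the direction remains open and the range must be wide. The expected move is a 1.3-fold higher number from compound 2 to compound 3 (0.10 log units; within the scatter), with no shift beyond the scatter anticipated. For compound 3 the estimated value is 4 ug/mL, within an expected range of 1.3 ug/mL to 12 ug/mL.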

Compound 3, half-maximal inhibitory concentration: 80 ug/mL
For compound 3 the middle estimate is 20-fold (1.30 log units) below the measured one, outside the stated range (above it).
By their numbers in this assay, from the lowest: compounds 1 and 2 (each within the scatter of the next); then compound 3.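

Among these compounds, the earlier pair showed only that one sulfur-linked aromatic ring could stand in for another on the saturated chain carbon bound to a carbonyl carbon, and the new result shows that this tolerance does not extend to every group there. In this assay, where a higher number means weaker inhibition, putting 4-(2-(dimethylamino)ethenyl)piperazin-1-yl in place of the sulfur-linked ring gives a 25-fold higher number from compound 2 to compound 3 (1.40 log units; beyond the scatter) and, with the other sulfur-linked ring as the starting point, a 25-fold higher number from compound 1 to compound 3 (1.40 log units; beyond the scatter), so the group on this chain carbon can strongly change the cytotoxicity read-out even with the shared core and the carbonyl kept. Nothing measured here explains why this exchange costs so much.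

The change removes the sulfur and the five-membered aromatic ring and brings in the piperazine ring and the dimethylamino-bearing ethenyl group all at once, so the compounds shown cannot assign the loss to any one of these parts. As far as these compounds go, a simpler group such as 4-methylpiperazin-1-yl, or a phenylsulfanyl group that keeps the sulfur, would be needed to separate them, and how either behaves remains open.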